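The compounds below may be only part of what the source reports. "The series", "measured", "known", "first", "only" and "open" are said of these compounds alone.

In a functional assay on KYSE-450 cells (Homo sapiens) for inhibition, read by MTT assay, with a stated time of 48 h (a higher number here means a weaker inhibitor, a lower number a stronger inhibitor), compound 1 `COc1ccc(CN(C(=O)C=C(C)C)c2cc(OC)c(OC)c(OC)c2)cc1O` gives 280 nM, compound 2 `C#CC(=O)N(Cc1ccc(OC)c(O)c1)c1cc(OC)c(OC)c(OC)c1` gives 570 nM and compound 3 `COc1ccc(CN(C(=O)CN=[N+]=[N-])c2cc(OC)c(OC)c(OC)c2)cc1O` gives 160 nM. Thus a 1.8-fold lower number from compound 1 to compound 3 (0.24 log units; within the scatter), whereas a 3.6-fold lower number from compound 2 to compound 3 (0.55 log units; beyond the scatter), so compound 3 shares the low end of this small range with compound 1. Compound 4 `COc1ccc(CN(C(=O)C[Se]C#N)c2cc(OC)c(OC)c(OC)c2)cc1O` alters compound 3 in one place: a group of 3 heavy atoms (1 carbon, 1 nitrogen, 1 selenium; no ring) in place of a group of 3 heavy atoms (3 nitrogen; no ring), on a saturated chain carbon bound to a carbonyl carbon. Going by the values given here, no measured compound carries the entering group, so the only guide is the other changes on the same side of the carbonyl, including a 2.0-fold higher number from compound 1 to compound 2 (0.31 log units; beyond the scatter). All of these steps were modest or smaller, so no step beyond the scatter is expected. Compound 4 is estimated at 150 nM, with a range from 50 nM to 450 nM. This expected step is a 1.1-fold lower number from compound 3 to compound 4 (0.03 log units; within the scatter).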

Compound 4, half-maximal inhibitory concentration: 280 nM
For compound 4 the middle estimate is 1.9-fold (0.27 log units) below the measured one, within the range that was stated.
By their numbers in this assay, from the lowest: compounds 3, 1 and 4 (each within the scatter of the next); then compound 2.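

On the saturated chain carbon bound to a carbonyl carbon, a selenium-containing group can replace azido without a step beyond the scatter (a 1.8-fold higher number from compound 3 to compound 4 (0.24 log units; within the scatter)). Compound 4 also matches compound 1 (no change at the digits printed from compound 1 to compound 4 (within the scatter)) and differs from compound 2 by a modest step (a 2.0-fold lower number from compound 2 to compound 4 (0.31 log units; beyond the scatter)), so this new group sits with the two lower compounds. No measurement here explains these numbers. Going by these compounds, whether an amine, a carboxylic acid or a longer chain carrying selenium at this place would keep the same level stays open.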